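Hydroxymethyl to 4-fluorobenzyl in a solubility series

This account rests on a few compounds, and the source may have more. Where it says the series, first, only, none or still open, it means among the compounds named here.

Compound 1 `Cc1cc(N[C@H](CCCCNCc2ccccc2F)C(=O)NO)cc(C)c1F` gives > 5 ug/mL
Compound 2 `CO[C@H](C[C@H](CCN1CCCC(CO)C1)C(=O)NO)c1ccc(F)cc1` gives > 5 ug/mL

In a physicochemical assay for solubility, in phosphate buffer (on this read-out lower numbers stand for lower solubility and higher numbers for higher solubility), compound 2 gives > 5 ug/mL and this is a limit, not a number. The measurements so far show only the limit of > 5 ug/mL in this assay, at which 2 of the 2 values shown sit, and no exact value. Compound 3 `CO[C@H](C[C@H](CCN1CCCC(Cc2ccc(F)cc2)C1)C(=O)NO)c1ccc(F)cc1` differs from compound 2 by one exchange, 4-fluorophenyl in place of hydroxy on a saturated chain carbon bound to a saturated ring carbon with 4-fluorophenyl in place of hydroxy on a saturated chain carbon bound to a saturated ring carbon. Within the data shown here, no measured step shows the size of such an exchange. In this assay a modest fall is expected, and an at least 1.2-fold lower number from compound 2 to compound 3 (0.09 log units; that floor lies within the scatter) is the estimated size of it. Compound 3 is estimated at 4 ug/mL in this assay with an expected range from 1 ug/mL to 10 ug/mL around it.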

Compound 3, solubility: > 5 ug/mL
Compound 3 was reported as a limit; the forecaster's own chance of this, stated with the estimate: 40%; at least 1.2-fold (0.09 log units) between middle value and limit.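

Compound 2 and compound 3 both give only a limit, so no step can be read between them: the limit of > 5 ug/mL in this assay, at which 3 of the 3 values shown sit.

The compounds shown leave open whether hydroxymethyl to 4-fluorobenzyl changes the read-out in this assay at all, and by how much.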